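The source may report more compounds than this note shows. Statements on the series, on what has been measured and on what is new or still open speak of the compounds shown alone.

Of the compounds shown here, three built on one shared core have been tested in a functional assay on MIA PaCa-2 cells (Homo sapiens) for cytotoxicity, read by MTT assay, with a stated time of 48 h; a lower number here means a stronger inhibitor, a higher number a weaker inhibitor. Compound 1 `c1ccc(-c2nc(-c3c[nH]c4ccccc34)co2)cc1` gives 113000 nM. Compound 2 `Fc1ccc(-c2nc(-c3c[nH]c4ccccc34)co2)cc1` gives 40600 nM, and compound 3 `C(=C/c1nc(-c2c[nH]c3ccccc23)co1)\c1ccccc1` gives 873000 nM. Compound 2 therefore has the lowest number of the three: compound 1 stands nearest to it, and compound 3 lies furthest away. Within the data shown here, the single measured step that can be followed, a 2.8-fold lower number from compound 1 to compound 2 (0.44 log units; beyond the scatter), comes from a small change on one ring. Compound 4 `c1ccc2c(-c3coc(C4CCNCC4)n3)c[nH]c2c1` differs from compound 2 in a larger way: piperidin-4-yl in place of 4-fluorophenyl on an aromatic carbon. Among the measured compounds shown here, no measured pair shows what happens when the whole aromatic ring at this position is exchanged for a non-aromatic ring, so the fluoro step offers only a weak guide, and the direction of the change in this assay cannot be read from the available data. Allowing for the wide spread among the three measured values, compound 4 is expected to give about 100000 nM, within a range from 15000 nM to 700000 nM. That estimate means an expected step of a 2.5-fold higher number from compound 2 to compound 4 (0.39 log units; beyond the scatter).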

Compound 4, half-maximal inhibitory concentration: 230000 nM
The estimate for compound 4 lay 2.3-fold (0.36 log units) below the measured number; measured number inside the range.
By their numbers in this assay, from the lowest: compound 2; then compound 1; then compound 4; then compound 3.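

In this assay the exchange of 4-fluorophenyl for piperidin-4-yl gives a 5.7-fold higher number from compound 2 to compound 4 (0.75 log units; beyond the scatter) and the exchange of plain phenyl for the same ring gives a 2.0-fold higher number from compound 1 to compound 4 (0.31 log units; beyond the scatter). Both steps point the same way and lie beyond the scatter, so this position now has a measured direction: here, a non-aromatic ring holding one nitrogen gives a weaker inhibitor than either aromatic ring, and the step from the fluorinated ring is the larger. No measurement is available to explain this change.

The piperidin-4-yl group differs from phenyl in both its lost aromatic character and its added ring nitrogen, and these two changes cannot be separated with the compounds shown. A cyclohexyl ring at this position would separate them, while a methyl group on the piperidine nitrogen would test that nitrogen and its hydrogen directly.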